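A few compounds are considered here, and "the series" means these few. Any claim that something is new, unique, unknown or untested is made for them only; others in the source may bear on it.

In a physicochemical assay for solubility, read by HPLC (on this read-out lower numbers stand for lower solubility and higher numbers for higher solubility), three compounds built on one shared core have been measured. Compound 1 `CCC(=O)N1CCN(c2nc(=O)c3cc(C(F)(F)F)cc([N+](=O)[O-])c3s2)CC1` gives 3.29 ug/mL. Compound 2 `O=C(c1ccc(F)cc1)N1CCN(c2nc(=O)c3cc(C(F)(F)F)cc([N+](=O)[O-])c3s2)CC1` gives 1.69 ug/mL, and compound 3 `Cc1ccc(C(=O)N2CCN(c3nc(=O)c4cc(C(F)(F)F)cc([N+](=O)[O-])c4s3)CC2)cc1` gives 6.7 ug/mL. Compound 3 has the highest of the three numbers: its nearest neighbour is compound 1, with a 2.0-fold higher number from compound 1 to compound 3 (0.31 log units; beyond the scatter), and its furthest is compound 2, with a 4.0-fold higher number from compound 2 to compound 3 (0.60 log units; beyond the scatter). Between the other two the step of a 1.9-fold lower number from compound 1 to compound 2 (0.29 log units; within the scatter) stays within the scatter.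

The next compound, compound 4 `CC(C)CC(=O)N1CCN(c2nc(=O)c3cc(C(F)(F)F)cc([N+](=O)[O-])c3s2)CC1`, differs from compound 3 in one place: isobutyl in place of 4-methylphenyl on a carbonyl carbon. Within the data shown here, two measured steps bear on this, both of which put an aromatic ring in place of the ethyl chain on the same carbonyl carbon, one going up, a 2.0-fold higher number from compound 1 to compound 3 (0.31 log units; beyond the scatter), and one going down, a 1.9-fold lower number from compound 1 to compound 2 (0.29 log units; within the scatter). Compound 4 goes the other way, from a ring back to a chain, and isobutyl is close in kind to the ethyl of compound 1. A modest fall is therefore expected, roughly undoing the rise seen in a 2.0-fold higher number from compound 1 to compound 3 (0.31 log units; beyond the scatter), so that the step is estimated as a 1.9-fold lower number from compound 3 to compound 4 (0.28 log units; within the scatter). Compound 4 is expected to give about 3.5 ug/mL, within a range from 1.5 ug/mL to 8 ug/mL.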

Compound 4, solubility: 66.3 ug/mL
For compound 4 the middle estimate is 19-fold (1.28 log units) below the measured one, outside the stated range (above it).
By their numbers in this assay, from the lowest: compounds 2 and 1 (each within the scatter of the next); then compound 3; then compound 4.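

In this assay the group on the carbonyl carbon proves able to move the number much further than compounds 1 to 3 showed: isobutyl in place of 4-methylphenyl gives a 9.9-fold higher number from compound 3 to compound 4 (1.00 log units; beyond the scatter) on this read-out, and isobutyl in place of 4-fluorophenyl gives a 39-fold higher number from compound 2 to compound 4 (1.59 log units; beyond the scatter) in the same series. The comparison of the two chains is just as striking. A chain in this place does not by itself set the number: going from the ethyl of compound 1 to the isobutyl of compound 4 gives a 20-fold higher number from compound 1 to compound 4 (1.30 log units; beyond the scatter) and is larger than any step among the first three compounds. No measurement at hand accounts for this jump.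

Among these compounds, with only two chains and two rings in this place, it remains open whether the high number belongs to isobutyl alone or would carry over to a longer chain, such as n-pentyl, or to a cyclohexyl ring. An amine or a carboxylic acid on the end of the chain would also be a different kind of test, and its effect on this read-out cannot be told from these four compounds.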